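The compounds below may be only part of what the source reports. "The series", "measured", "known", "first", "only" and "open" are said of these compounds alone.

Measured compounds:
- compound 1 `O=C(NCCC1CCN(Cc2ccccc2)CC1)c1coc2ccc(OCc3ccccc3)cc2c1=O`: 272 nM
- compound 2 `Cc1ccc2occ(C(=O)NCCC3CCN(Cc4ccccc4)CC3)c(=O)c2c1`: 52500 nM

In an assay on isolated protein for inhibition of Amine oxidase [flavin-containing] B (Homo sapiens), read by fluorescence and Amplex Red, with stated times of 15 min and 20 min (on this read-out higher numbers stand for weaker inhibition and lower numbers for stronger inhibition), compound 1 gives 272 nM. In this assay compound 2 gives 52500 nM, the highest of the two numbers; its nearest neighbour is compound 1, with the step of a 190-fold higher number from compound 1 to compound 2 (2.29 log units; beyond the scatter) separating them, a large move that lies beyond the scatter.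

Compound 3 `O=C(NCCC1CCN(Cc2ccccc2)CC1)c1coc2ccc(Br)cc2c1=O` has not yet been measured in this assay. It differs from compound 2 by bromo in place of methyl on an aromatic carbon. Among the measured compounds shown here, of the measured steps only the move from compound 1 to compound 2 exists, and it concerns a different exchange, benzyloxy against methyl; no measured step shows bromo against methyl on that aromatic carbon. Since both methyl and bromo are single heavy atoms with no ring, the large step of a 190-fold higher number from compound 1 to compound 2 (2.29 log units; beyond the scatter) does not itself argue for a change of similar size here, and a step within the scatter, or a small one, is expected in this assay.

Compound 3 is therefore estimated at 30000 nM, with a range from 8000 nM to 110000 nM, which would mean an expected step of a 1.8-fold lower number from compound 2 to compound 3 (0.24 log units; within the scatter).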

Compound 3, half-maximal inhibitory concentration: 26100 nM
Compound 3: the middle estimate sits 1.1-fold (0.06 log units) above what was measured; the measured number falls inside the stated range.
By their numbers in this assay, from the lowest: compound 1; then compounds 3 and 2 (each within the scatter of the next).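

In this assay, bromo in place of methyl on this aromatic carbon gives a 2.0-fold lower number from compound 2 to compound 3 (0.30 log units; within the scatter), so the two single-heavy-atom groups cannot be told apart at this position. Bromo in place of benzyloxy gives a 96-fold higher number from compound 1 to compound 3 (1.98 log units; beyond the scatter), a large step of the same kind as a 190-fold higher number from compound 1 to compound 2 (2.29 log units; beyond the scatter); the earlier gap was therefore not peculiar to methyl, and compound 1, with benzyloxy, remains the strongest inhibitor of the three. What lies behind this gap cannot be said, since no supporting observation accompanies these numbers.

The compounds shown leave open which part of benzyloxy carries the difference, and a methoxy group, which keeps the oxygen without the phenyl ring, would begin to separate the two. They also leave open whether a longer chain ending in a phenyl ring would go beyond compound 1, and how a plain hydrogen, an amine or a carboxylic acid on this carbon would compare with bromo and methyl.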